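Adding a chloro group to an inactive compound

The compounds below may be only part of what the source reports. "The series", "measured", "known", "first", "only" and "open" are said of these compounds alone.

Compound 1 `CC1(C)OC2O[C@@H](Cc3cn4ccccc4nc3=O)C(OCc3ccccc3)C2O1`: > 1000000 nM
Compound 2 `O=c1nc2ccccn2cc1Cc1ccc(F)cc1`: > 1000000 nM

Going by the values given here, only two compounds have been measured in a functional assay on HepG2 cells (Homo sapiens) for cytotoxicity, read by MTT assay, with a stated time of 24 h (on this read-out higher numbers stand for weaker inhibition and lower numbers for stronger inhibition), and neither gives a number. Compound 1 stands at > 1000000 nM, which is a limit of the assay and not a measured value. Compound 2 stands at > 1000000 nM, which is also a limit. Together they give one shared result: the limit of > 1000000 nM in this assay, at which 2 of the 2 values shown sit. The two compounds therefore cannot be ranked against each other.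

Compound 3 `CC1(C)OC2O[C@@H](Cc3cn4cc(Cl)ccc4nc3=O)C(OCc3ccccc3)C2O1` keeps the core of compound 1 and changes it in one place (chloro in place of hydrogen on an aromatic carbon). It carries chloro in place of hydrogen on an aromatic carbon, two atoms from the ring nitrogen. Among the compounds with values here, no measured pair shows a change of this kind, so the expectation rests on compound 1 and its limit of > 1000000 nM. The estimated step of a number no higher from compound 1 to compound 3 (the limit leaves the size open) is expected to stay within the usual scatter, with no clear direction, and the assay may well report only a limit again. For compound 3 the estimated value in this assay is 1000000 nM, with an expected range from 400000 nM to 2000000 nM.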

Compound 3, half-maximal inhibitory concentration: > 1000000 nM
Compound 3 was reported as a limit; the forecaster's own chance of this, stated with the estimate: 75%; the middle value sits exactly at the limit.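

In this assay compound 3 gives > 1000000 nM, which is a limit and not a number. No step from compound 1 to compound 3 can be read, because both compounds sit at a limit: the limit of > 1000000 nM in this assay, at which 3 of the 3 values shown sit.

Going by these compounds, whether chloro in place of hydrogen on an aromatic carbon shifts the value at all, and in which direction, stays open.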